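This account rests on a few compounds, and the source may have more. Where it says the series, first, only, none or still open, it means among the compounds named here.

Compound 1, `C[C@@H]1C(=O)[C@H]2C[C@]1(O)CC1=C2[C@]2(C)CCC[C@](C)(CO)[C@H]2CC1`, in a functional assay on SAOS-2 cells (Homo sapiens) for cytotoxicity, read by MTT assay, with a stated time of 24 h (on this read-out higher numbers stand for weaker inhibition and lower numbers for stronger inhibition), gives > 50000 nM, which is a limit of the assay and not a number.
Compound 2, `C[C@@H]1C(=O)[C@H]2C[C@]1(O)CC1=C2[C@]2(C)CCCC(C)(C)[C@H]2CC1`, in this assay gives > 50000 nM, again a limit of the assay.
Compound 3, `C[C@@H]1C(=O)[C@H]2C[C@]1(O)CC1=C2[C@]2(C)CCC[C@](C)(C=O)[C@H]2CC1`, in this assay gives > 50000 nM, also a limit of the assay.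

Among the compounds with values here, compound 2 therefore stands at a limit in this assay, and the two further values shown are limits as well, so no compound here sets a number against which it could be ranked; the limit of > 50000 nM in this assay, at which 3 of the 3 values shown sit, is the whole of the evidence.

The step to compound 4, `C[C@@H]1C(=O)[C@H]2C[C@]1(O)CC1=C2[C@]2(C)CCC[C@@](C)(CO)[C@H]2CC1`, is hydroxy in place of hydrogen on a saturated chain carbon bound to a saturated ring carbon. The measured steps that bear on it are a step that the two limits leave unreadable from compound 1 to compound 2, which is the same change run in the opposite direction, and a step that the two limits leave unreadable from compound 1 to compound 3, which alters the hydroxymethyl group rather than adding a hydroxy. Neither step can be read in size, and every value behind them sits at the same limit, so the data give no direction for the change and no size beyond the scatter can be expected.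

Compound 4 is accordingly expected to remain at or near the limit in this assay, with an estimated value of 80000 nM and a range from 30000 nM to 300000 nM, the expected step being a step that the limit leaves unreadable from compound 2 to compound 4.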

Compound 4, half-maximal inhibitory concentration: > 50000 nM
Compound 4: no number, only a limit; the forecaster's own chance of this, stated with the estimate: 90%; the middle value does not contradict the limit.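

In this assay compound 4 gives > 50000 nM, again a limit of the assay and not a number. Within the data shown here, no step among compound 1, compound 2 and compound 4 can be read in size. The compounds shown leave open whether any of these changes, including the configuration that alone separates compound 1 and compound 4, alters cytotoxicity at all: the limit of > 50000 nM in this assay, at which 4 of the 4 values shown sit.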